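Trifluoromethyl in place of ethoxy on compound 2

A few compounds are considered here, and "the series" means these few. Any claim that something is new, unique, unknown or untested is made for them only; others in the source may bear on it.

Among the measured compounds shown here, in a toxicity assay on microsomes from liver (Homo sapiens) for metabolic stability, read by LC-MS, using NADPH, tested at 1 uM (on this read-out higher numbers stand for fast clearance and lower numbers for slow clearance), compound 2 `CCOc1ccc(-c2nc(C(F)(F)F)sc2N2CCN(C(=O)Cn3nc(C)nc3C)[C@H](C)C2)cn1` gives 66 mL.min-1.g-1, the lower of the two numbers measured so far, while compound 1 `Cc1nc(C)n(CC(=O)N2CCN(c3sc(C(F)(F)F)nc3-c3cnc(N4CCCC4)nc3)C[C@H]2C)n1` gives 338 mL.min-1.g-1. For the measured compounds named here, the one measured step, a 5.1-fold lower number from compound 1 to compound 2 (0.71 log units; beyond the scatter), came with 6-ethoxypyridin-3-yl in place of 2-(pyrrolidin-1-yl)pyrimidin-5-yl on an aromatic carbon, and it was modest. Compound 3 `Cc1nc(C)n(CC(=O)N2CCN(c3sc(C(F)(F)F)nc3-c3ccc(C(F)(F)F)nc3)C[C@H]2C)n1` carries trifluoromethyl in place of ethoxy on an aromatic carbon, next to the ring nitrogen and para to a large group (trifluoromethyl in place of ethoxy on an aromatic carbon). Going by the values given here, the earlier step bears on this only loosely: it replaced a whole group, and no measured pair compares ethoxy with trifluoromethyl directly. A smaller step towards a lower number is expected in this assay, possibly within the scatter, and the estimated change is a 1.6-fold lower number from compound 2 to compound 3 (0.20 log units; within the scatter). The estimate for compound 3 is 42 mL.min-1.g-1, with an expected range from 16 mL.min-1.g-1 to 110 mL.min-1.g-1.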

Compound 3, intrinsic clearance in microsomes: < 10 mL.min-1.g-1
Compound 3 was reported as a limit; the forecaster's own chance of this, stated with the estimate: 3%; middle value at least 4.2-fold (0.62 log units) away from the limit.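

In this assay, the exchange of ethoxy for trifluoromethyl on an aromatic carbon, next to the ring nitrogen and para to a large group, gave an at least 6.6-fold lower number from compound 2 to compound 3 (0.81 log units; beyond the scatter). This shows that a change of this one substituent moves the read-out beyond the scatter, which the earlier pair could not show, since it replaced a whole group and left ethoxy and trifluoromethyl uncompared. Measured against the group carried by compound 1, the 6-(trifluoromethyl)pyridin-3-yl group gave an at least 33-fold lower number from compound 1 to compound 3 (1.52 log units; beyond the scatter), and the value of compound 3 is a limit, not a number: the limit of < 10 mL.min-1.g-1 in this assay, at which 1 of the 3 values shown sits.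

As far as these compounds go, the full size of both steps therefore stays open. Also open, from the compounds shown here alone, is how a methoxy group or a nitrile on the same carbon would read in this assay.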